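Methylating the amine of an inactive amide

This account rests on a few compounds, and the source may have more. Where it says the series, first, only, none or still open, it means among the compounds named here.

Compound 1 `CN(CCN)Cc1ccccc1` is a small fragment that, in an assay on isolated protein for inhibition of protein arginine N-methyltransferase 6 (Homo sapiens) (on this read-out lower numbers stand for stronger inhibition and higher numbers for weaker inhibition), gives 2500 nM. Compound 2 `C[C@H](N)C(=O)NCc1cccnc1N(C)Cc1ccccc1` carries an amide built onto a larger core, and in this assay compound 2 gives "not active" (no number reported). Compound 3 `C[C@@H](N)C(=O)NCc1cccnc1Oc1ccc(F)cc1F` shares that amide but a different group on the core; in this assay compound 3 gives "not active" (no number reported), so no number stands for it, as for compound 2. Compound 4 `CN[C@@H](C)C(=O)NCc1cccnc1Oc1ccc(F)cc1F` is the next step, differing from compound 3 in one place: 1-(methylamino)ethyl in place of 1-aminoethyl on a carbonyl carbon. For the measured compounds named here, no measured pair shows what such a change does here, and compound 3 itself lacks a number to step from. Given that compound 3 gives only "not active" (no number reported), the expectation for compound 4 is weak inhibition as well, with a fair chance that this assay again reports no number. Compound 4 is expected to give about 10000 nM in this assay, in a range from 2000 nM to 50000 nM.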

Compound 4, half-maximal inhibitory concentration: "not active" (no number reported)
No number was reported for compound 4, so the estimate cannot be set against anything.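

Compound 3 and compound 4 both give no number in this assay, so no step can be read between them, and no evidence here bears on this result. From the compounds shown here alone, what the 1-(methylamino)ethyl group in place of 1-aminoethyl does to inhibition remains open.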